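Removing a Methylsulfanyl Group: Expected Oral Bioavailability

The source may report more compounds than this note shows. Statements on the series, on what has been measured and on what is new or still open speak of the compounds shown alone.

Of the compounds shown here, two have been measured in an in vivo ADME assay on the whole organism (strain C57BL/cAnNCrl) for pharmacokinetics, with Mus musculus as the target, at a dose of 10 mg/kg by the oral route; a higher number here means that a larger share of the oral dose reaches the circulation, a lower number that a smaller share of the oral dose reaches the circulation. Compound 1 `Cc1nc2c(Oc3ccc(NC(=O)Nc4cc(C(F)(F)F)ccc4F)c4ccccc34)ccnc2[nH]c1=O` gives 4%. Compound 2 `CSc1cc(Oc2ccnc3[nH]c(=O)cnc23)ccc1NC(=O)Nc1cc(C(C)(C)C)nn1-c1ccc(C)cc1` gives 71%, the higher of the two numbers, and the gap to compound 1 lies beyond the usual scatter. A third compound, compound 3 `Cc1ccc(-n2nc(C(C)(C)C)cc2NC(=O)Nc2ccc(Oc3ccnc4[nH]c(=O)cnc34)cc2)cc1`, has not yet been measured. It differs from compound 2 in a single place: hydrogen in place of methylsulfanyl on an aromatic carbon of a six-membered aromatic ring of carbon only, ortho to a large group and meta to a large group. Within the data shown here, no measured pair shows what such a change does, so the expectation rests on compound 2 alone. In this assay the change is expected to cost little, most likely a modest fall that may stay within the scatter, and a number 11 percentage points lower from compound 2 to compound 3 (beyond the scatter) is the step this expectation means. Compound 3 is therefore expected to give about 60%, within a range from 30% to 85%.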

Compound 3, oral bioavailability: 17%
Compound 3: the middle estimate sits 43 percentage points above what was measured, and the stated range ends above it.
By their numbers in this assay, from the lowest: compound 1; then compound 3; then compound 2.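

In this assay, replacing the methylsulfanyl group with hydrogen on this aromatic carbon gives a number 54 percentage points lower from compound 2 to compound 3 (beyond the scatter), so this change at this position is a large one. Compound 1 and compound 2 differ in many places, so their gap could not be tied to any single part of the structure, whereas this pair ties a large difference to one place. Nothing among the available data explains why so small a change moves the read-out this far.

Among the compounds shown, this carbon carries only methylsulfanyl or hydrogen, so it stays open whether a methoxy group, a chlorine atom or a longer chain such as ethylsulfanyl would give a number nearer that of compound 2. This is also a single pair, so it cannot show whether the same change would have a similar effect on another compound.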